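Purine series: one-methyl chain extension on the side chain

The source may report more compounds than this note shows. Statements on the series, on what has been measured and on what is new or still open speak of the compounds shown alone.

Values in a functional assay on SW480 cells (Homo sapiens) for antiproliferative activity, read by MTT assay, with a stated time of 48 h; on this read-out lower numbers stand for stronger inhibition and higher numbers for weaker inhibition:
compound 1 `CCCCCC(CCO)n1c(Br)nc2c(Cl)ncnc21` — 23800 nM
compound 2 `CCCCCCC(CCO)n1c(Br)nc2c(Cl)ncnc21` — 14100 nM
compound 3 `CCCCCCCC(CCO)n1cnc2c(Cl)nc(F)nc21` — 26100 nM

The change methyl in place of hydrogen on a saturated chain carbon, six bonds along the chain from an aromatic nitrogen gave a 1.7-fold lower number from compound 1 to compound 2 (0.23 log units; within the scatter). The difference between the cores of compound 1 and compound 3 is not broken down here. Compound 4 `CCCCCCCCC(CCO)n1cnc2c(Cl)nc(F)nc21`, not yet measured, carries the same kind of change from compound 3: methyl in place of hydrogen on a saturated chain carbon, eight bonds along the chain from an aromatic nitrogen. The surroundings of the place differ in that the methyl enters eight bonds along the chain from an aromatic nitrogen, against six bonds in the measured pair. For compound 4 the expected step is a 1.5-fold lower number from compound 3 to compound 4 (0.16 log units; within the scatter). This expectation rests on a 1.7-fold lower number from compound 1 to compound 2 (0.23 log units; within the scatter), which lay within the scatter, and on compound 3 at 26100 nM. Compound 4 is therefore expected to give about 18000 nM in this assay, most likely between 8000 nM and 40000 nM.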

Compound 4, half-maximal inhibitory concentration: 15000 nM
Compound 4: the middle estimate sits 1.2-fold (0.08 log units) above what was measured; the range from low to high includes it.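

In this assay, the added methyl gave a 1.7-fold lower number from compound 3 to compound 4 (0.24 log units; within the scatter), so this step alone shows no real change in activity. Set beside the earlier step, the same change reads alike on the two cores: the same change on two cores in this assay, a 1.7-fold lower number (0.23 log units; within the scatter) from compound 1 to compound 2 and a 1.7-fold lower number (0.24 log units; within the scatter) from compound 3 to compound 4, 1.0-fold (0.01 log units) apart, within the scatter of two such steps. The change therefore carries from one core to the other without a detectable difference between the two steps, but this does not show that the methyl improves activity on either core, as each step lies within the scatter.

Still open, on these data alone, is whether a longer chain would give a step of the same size on either core. Also open, as far as these compounds go, is how an amine or a carboxylic acid in place of the hydroxyl would read.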